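Dichlorophenyl isomers on the triazole nitrogen

The source may report more compounds than this note shows. Statements on the series, on what has been measured and on what is new or still open speak of the compounds shown alone.

Compound 1: `CC(=O)Nc1ccc(-n2nncc2CN2C(=O)C3(C(C#N)=C(N)Oc4c(N)cc5nc6ccccc6nc5c43)c3ccccc32)cc1` — > 50000 nM
Compound 2: `N#CC1=C(N)Oc2c(N)cc3nc4ccccc4nc3c2C12C(=O)N(Cc1cnnn1-c1ccc(Cl)cc1Cl)c1ccccc12` — > 50000 nM

In a functional assay on MCF7 cells (Homo sapiens) for antiproliferative activity, read by MTT assay, with a stated time of 48 h (a lower number here means a stronger inhibitor, a higher number a weaker inhibitor), compound 1 gives only a limit, > 50000 nM. Compound 2 likewise gives only a limit, > 50000 nM. The step that the two limits leave unreadable from compound 1 to compound 2 cannot be read, since (the limit of > 50000 nM in this assay, at which 2 of the 2 values shown sit). Compound 2 therefore stands at the limit, with no number.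

Compound 3 is `N#CC1=C(N)Oc2c(N)cc3nc4ccccc4nc3c2C12C(=O)N(Cc1cnnn1-c1cc(Cl)ccc1Cl)c1ccccc12`; it differs from compound 2 by 2,5-dichlorophenyl in place of 2,4-dichlorophenyl on an aromatic nitrogen. Going by the values given here, the only measured step, a step that the two limits leave unreadable from compound 1 to compound 2, bears on a change at the same place but gives no size, so no direction is expected beyond the scatter. Compound 3 is expected at 50000 nM, between 20000 nM and 100000 nM, a step of a number no higher from compound 2 to compound 3 (the limit leaves the size open), most likely again a limit.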

Compound 3, half-maximal inhibitory concentration: 33200 nM
Beside the measured number, compound 3's estimate is 1.5-fold (0.18 log units) above it; measured number inside the range.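

In this assay, compound 3 alone among the three gives a number rather than a limit, with an at least 1.5-fold lower number from compound 2 to compound 3 (0.17 log units; that floor lies within the scatter) and an at least 1.5-fold lower number from compound 1 to compound 3 (0.17 log units; that floor lies within the scatter). Compounds 2 and 3 have the same atoms, so the change is only from 2,4-dichlorophenyl to 2,5-dichlorophenyl on the aromatic nitrogen. Both steps are floors within the scatter, so neither establishes a real gain or gives its true size.

Still open, from the compounds shown here alone, is whether an amine or a carboxylic acid on this phenyl ring would give a clearly lower number.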